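The source may report more compounds than this note shows. Statements on the series, on what has been measured and on what is new or still open speak of the compounds shown alone.

Measured compounds:
- compound 1 `NC(=O)c1c(NC(=O)c2ccccc2Cl)sc2c1CCN(C(=S)Nc1ccccc1Br)C2`, in a functional assay on HL-60 cells (Homo sapiens) for antiproliferative activity, with a stated time of 24 h (on this read-out higher numbers stand for weaker inhibition and lower numbers for stronger inhibition), compound 1 gives 9090 nM
- compound 2 `COc1ccc(NC(=S)N2CCc3c(sc(NC(=O)c4ccccc4Cl)c3C(N)=O)C2)cc1`, in this assay compound 2 gives 15700 nM

Both compounds share one core and differ only in the aryl group attached to the thiourea nitrogen. Compound 2 holds the higher of the two numbers, but the step of a 1.7-fold higher number from compound 1 to compound 2 (0.24 log units; within the scatter) is within the scatter, so the two values cannot be told apart with confidence.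

Compound 3 `NC(=O)c1c(NC(=O)c2ccccc2Cl)sc2c1CCN(C(=S)Nc1cccnc1)C2` is the next variation at the same place: pyridin-3-yl in place of 4-methoxyphenyl on an amide-type nitrogen. Among the measured compounds shown here, the only measured step that touches this position is the swap from compound 1 to compound 2, which changed one aryl group for another and produced a difference no larger than the scatter. With a single such comparison, and that one flat, there is no ground to expect the pyridin-3-yl group to move the number beyond the scatter in either direction.

The estimate for compound 3 is therefore close to compound 2, a step of a 1.2-fold lower number from compound 2 to compound 3 (0.08 log units; within the scatter), giving an expected value of 13000 nM with a range from 4500 nM to 40000 nM.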

Compound 3, half-maximal inhibitory concentration: 33900 nM
Compound 3: middle estimate off by 2.6-fold (0.42 log units), on the low side; the range from low to high includes it.
By their numbers in this assay, from the lowest: compounds 1 and 2 (each within the scatter of the next); then compound 3.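

In this assay, the group on the amide-type nitrogen is not freely interchangeable after all: the change to pyridin-3-yl brings a 2.2-fold higher number from compound 2 to compound 3 (0.33 log units; beyond the scatter) and a 3.7-fold higher number from compound 1 to compound 3 (0.57 log units; beyond the scatter), so compound 3 is the weakest of the three, although both steps are modest. Among the compounds shown here, the earlier swap between two substituted rings of carbon only stayed within the scatter, and this is the first sign that the aryl group here can shift the number, with the ring holding a hetero atom on the weaker side in this single example. No measurement shown explains why the number rises with this change.

Compound 3 differs from compound 2 in two ways at once, since it gains a ring nitrogen and loses the methoxy group, and the compounds shown cannot separate these two changes. A plain phenyl ring would help to separate them, while pyridin-4-yl would show whether the place of the ring nitrogen matters, and a cyclohexyl ring would show whether an aromatic ring is needed on this nitrogen at all.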